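The compounds below may be only part of what the source reports. "The series", "measured", "known", "first", "only" and "open" are said of these compounds alone.

Working notes on the aryl esters of the shared core. In a functional assay on MCF7 cells (Homo sapiens) for antiproliferative activity, read by MTT assay, with a stated time of 72 h (on this read-out higher numbers stand for weaker inhibition and lower numbers for stronger inhibition), compound 3 `CC1=CC[C@H]2[C@H](CC[C@]2(C)O)C(C)(C)[C@@H]1CC[C@H]1[C@]2(C)CC[C@H](OC(=O)c3cccc([N+](=O)[O-])c3)C(C)(C)O[C@H]2CC[C@@]1(C)O` gives 36000 nM and compound 2 `CC1=CC[C@H]2[C@H](CC[C@]2(C)O)C(C)(C)[C@@H]1CC[C@H]1[C@]2(C)CC[C@H](OC(=O)c3ccc([N+](=O)[O-])cc3)C(C)(C)O[C@H]2CC[C@@]1(C)O` gives 21600 nM, with a 1.7-fold higher number from compound 2 to compound 3 (0.22 log units; within the scatter). Compound 1 `CC1=CC[C@H]2[C@H](CC[C@]2(C)O)C(C)(C)[C@@H]1CC[C@H]1[C@]2(C)CC[C@H](OC(=O)NS(=O)(=O)c3ccc(C)cc3)C(C)(C)O[C@H]2CC[C@@]1(C)O` reads > 50000 nM, which is a limit of the assay. The steps measured from it are floors: an at least 2.3-fold lower number from compound 1 to compound 2 (0.36 log units; beyond the scatter) and an at least 1.3-fold lower number from compound 1 to compound 3 (0.14 log units; that floor lies within the scatter).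

Compound 4 `CC1=CC[C@H]2[C@H](CC[C@]2(C)O)C(C)(C)[C@@H]1CC[C@H]1[C@]2(C)CC[C@H](OC(=O)c3ccc(C(F)(F)F)cc3F)C(C)(C)O[C@H]2CC[C@@]1(C)O` carries 2-fluoro-4-(trifluoromethyl)phenyl in place of 3-nitrophenyl on a carbonyl carbon. Within the data shown here, the closest precedent is the exchange of one aryl group for another on that carbonyl carbon, seen between compound 2 and compound 3, where a 1.7-fold higher number from compound 2 to compound 3 (0.22 log units; within the scatter) stayed within the scatter. The steps from compound 1 replace a different kind of group and say little about this change. No step beyond the scatter is therefore expected in this assay, and the estimated step is a 1.2-fold lower number from compound 3 to compound 4 (0.08 log units; within the scatter). For compound 4 the expected value is 30000 nM, within an estimated range of 12000 nM to 50000 nM.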

Compound 4, half-maximal inhibitory concentration: > 50000 nM
Compound 4 gave a limit, no number; the forecaster's own chance of this, stated with the estimate: 20%; middle value at least 1.6-fold (0.22 log units) away from the limit.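

Compound 4 in this assay reads as a limit of the assay, so the steps to it are floors. Exchanging 4-nitrophenyl for 2-fluoro-4-(trifluoromethyl)phenyl on this carbonyl carbon gives the only aryl-for-aryl step shown beyond the scatter (an at least 2.3-fold higher number from compound 2 to compound 4 (0.36 log units; beyond the scatter)), so the choice of aryl group can matter here, whereas the floor against 3-nitrophenyl (an at least 1.3-fold higher number from compound 3 to compound 4 (0.14 log units; that floor lies within the scatter)) lies within the scatter and establishes no change. The step from compound 1 to compound 4 cannot be read, with a limit at each end.

Going by these compounds, how far compound 4 lies past the limit stays open, and the ceiling constrains the whole set: the limit of > 50000 nM in this assay, at which 2 of the 4 values shown sit. Also open, on these data alone, is whether an aryl ester carrying an amine or a carboxylic acid, or a simple acetate ester, would give a value lower than those of compound 2 and compound 3.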